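Fluoro to bromo: half-life notes on the series

The source may hold more compounds than are shown below. What is called first, only, known or untested is meant among the compounds shown, and "the series" means these compounds.

Three compounds of the series carry numbers in an ADME assay on the whole organism for metabolic stability, with Rattus norvegicus as the target; a lower number here means that the compound disappears faster, a higher number that the compound lasts longer. Compound 1 `CNC(=N)c1cccc(/C(C)=C(/F)C(=O)Nc2ccc(-c3ccncc3S(N)(=O)=O)cc2)c1` gives 3.23 h in this assay. Compound 2 `CN(C)c1nccc2ccc(/C=C\C(=O)Nc3ccc(-c4ccccc4S(N)(=O)=O)cc3)cc12` gives 1.51 h in this assay. Compound 3 `C/C(=C(\F)C(=O)Nc1ccc(-c2ccccc2S(N)(=O)=O)cc1F)c1ccc2ccnc(N)c2c1` gives 1.7 h in this assay. All three numbers lie within the usual scatter of one another, so compound 3 is not set apart from either compound 1 or compound 2 on this read-out. Among the compounds with values here, no pair among the three differs in only one place, so no single structural step can be read from the measured set.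

Compound 4 `C/C(=C(\F)C(=O)Nc1ccc(-c2ccccc2S(N)(=O)=O)cc1Br)c1ccc2ccnc(N)c2c1` has not yet been measured in this assay. It differs from compound 3 in one place: bromo in place of fluoro on an aromatic carbon, the position being ortho to a large group and meta to the 2-sulfamoylphenyl group. Within the data shown here, no measured pair shows how a halogen swap of this kind moves the half-life, so the expected step of no change at the digits printed from compound 3 to compound 4 (within the scatter) is none beyond the scatter. Compound 4 is estimated at 1.7 h, with an expected range from 0.85 h to 3.4 h.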

Compound 4, half-life: 1.6 h
The estimate for compound 4 lay 1.1-fold (0.03 log units) above the measured number; the measured number falls inside the stated range.
By their numbers in this assay, from the lowest: compounds 2, 4, 3 and 1 (each within the scatter of the next, the first and the last beyond it).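

In this assay, bromo in place of fluoro on an aromatic carbon, ortho to a large group and meta to a 2-sulfamoylphenyl group, gives a 1.1-fold lower number from compound 3 to compound 4 (0.03 log units; within the scatter) as the only single-place step shown for the series. Within the data shown here, at this position, then, the exchange of these two halogens leaves the half-life inseparable from the scatter, a reading that the earlier compounds, with no pair differing in one place, could not give. Nothing available bears on why the step is this size.

From the compounds shown here alone, the position is covered by fluoro and bromo alone, so the half-life with an amine, a carboxylic acid or a longer chain there remains open. Going by these compounds, whether the same halogen exchange would give a similar step on the core of compound 1 or compound 2 also remains open.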